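The source may hold more compounds than are shown below. What is called first, only, known or untested is meant among the compounds shown, and "the series" means these compounds.

Working notes on the series. The compounds share one core and differ only in the group on a saturated chain carbon bound to an oxygen next to a carbonyl group. Within the data shown here, in an assay for inhibition of serine/threonine-protein kinase PAK 4 (Homo sapiens), read by FRET and Z'-LYTE, with a stated time of 60 min, tested at 50 uM, in the presence of a further agent that is not named here (a higher number here means a stronger effect of the compound at the concentration tested, a lower number a weaker effect), compound 2 `C[C@@H]1CN(C(=O)c2nc(Nc3cc(C4CC4)[nH]n3)c3cc(Cl)ccc3n2)CCN1C(=O)OCc1ccccc1` gives 96%, the highest of the three numbers so far. Compound 3 `C[C@@H]1CN(C(=O)c2nc(Nc3cc(C4CC4)[nH]n3)c3cc(Cl)ccc3n2)CCN1C(=O)OCC(Cl)(Cl)Cl` gives 82.8% in this assay, and compound 1 `CCCCCOC(=O)N1CCN(C(=O)c2nc(Nc3cc(C4CC4)[nH]n3)c3cc(Cl)ccc3n2)C[C@H]1C` gives 32.7%. The measured steps are a number 63.3 percentage points higher from compound 1 to compound 2 (beyond the scatter), a number 50.1 percentage points higher from compound 1 to compound 3 (beyond the scatter) and a number 13.2 percentage points lower from compound 2 to compound 3 (beyond the scatter).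

Compound 4 `CC(C)COC(=O)N1CCN(C(=O)c2nc(Nc3cc(C4CC4)[nH]n3)c3cc(Cl)ccc3n2)C[C@H]1C` has not yet been measured in this assay. Against compound 2 the change is isopropyl in place of phenyl on a saturated chain carbon bound to an oxygen next to a carbonyl group. The step that bears most directly on it is a number 63.3 percentage points higher from compound 1 to compound 2 (beyond the scatter), where an alkyl gave way to phenyl at the same place and the number rose strongly; the present change runs the other way, phenyl giving way to an alkyl, so a drop is expected. Among the measured compounds shown here, the alkyl entering is not the butyl of compound 1, and no measured pair shows what isopropyl does at this place, so the size of the drop is uncertain. Compound 4 is therefore expected to give 55% in this assay, with a range from 25% to 85%. The expected step is a number 41 percentage points lower from compound 2 to compound 4 (beyond the scatter).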

Compound 4, a percentage reported as inhibition, at one concentration (the size of the read-out at that concentration, not a potency): 46.9%
Beside the measured number, compound 4's estimate is 8.1 percentage points above it; low and high end bracket the measured number.
By their numbers in this assay, from the lowest: compound 1; then compound 4; then compound 3; then compound 2.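

Isopropyl on a saturated chain carbon bound to an oxygen next to a carbonyl group shows that the loss on leaving phenyl is not confined to butyl: in this assay the step is a number 49.1 percentage points lower from compound 2 to compound 4 (beyond the scatter), and trichloromethyl also holds a clear margin over this alkyl group, with a number 35.9 percentage points lower from compound 3 to compound 4 (beyond the scatter). The two alkyl groups are not interchangeable, since isopropyl recovers a modest part of the gap left by butyl, with a number 14.2 percentage points higher from compound 1 to compound 4 (beyond the scatter), yet among these four compounds butyl and isopropyl still give the two lowest numbers, and no compound goes against that split. No measurement offered here accounts for any of these differences.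

On these data alone, it remains open whether a cyclohexyl group at this place would keep the number of the phenyl of compound 2 or fall toward the alkyl compounds, which would separate the presence of a ring from its aromatic character. Also open, as far as these compounds go, is how a methoxy group or a chlorine on that phenyl would act, and, as every number comes from one concentration, how these compounds rank in potency.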